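Swapping the Side Chain of Compound 3

The compounds below may be only part of what the source reports. "The series", "measured", "known", "first", "only" and "open" are said of these compounds alone.

Measured in a functional assay on the whole organism (Tail, strain ICR) with Mus musculus as the target, in the tail flick test, with a stated time of 30 min, at a dose of 25 umol/kg by the oral route; on this read-out lower numbers stand for a weaker effect and higher numbers for a stronger effect at the one dose given:
Compound 1, `N=C(N)NCCC[C@H](NC(=O)CN(c1nc(Cl)nc2[nH]cnc12)C1CC1)C(=O)O`: 45.4%
Compound 2, `O=C(CN(c1nc(Cl)nc2[nH]cnc12)C1CC1)N[C@@H](CO)C(=O)O`: 38.7%
Compound 3, `CC[C@H](C)[C@H](NC(=O)CN(c1ncnc2c1ncn2C1CCCCO1)C1CC1)C(=O)OCc1ccccc1`: 25.6%

Compound 3 stands lowest of the three numbers in this assay, beyond the scatter below both compound 2 and compound 1. Compound 4, `CSCC[C@H](NC(=O)CN(c1ncnc2c1ncn2C1CCCCO1)C1CC1)C(=O)OCc1ccccc1`, differs from compound 3 in one place: 2-(methylsulfanyl)ethyl in place of sec-butyl on a saturated chain carbon bound to an amide-type nitrogen and a carbonyl carbon. Among the measured compounds shown here, no measured step alters this group at this place. For the measured compounds named here, the single measured step, a number 6.7 percentage points lower from compound 1 to compound 2 (within the scatter), replaced a different group elsewhere on the chain and stayed within the scatter. On that thin basis the step from compound 3 to compound 4 is expected to be small, a number 0.4 percentage points higher from compound 3 to compound 4 (within the scatter), with no direction called. Compound 4 is therefore estimated at 26%, in a range from 10% to 42%.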

Compound 4, a percentage reported as activity, at one dose (the size of the read-out at that dose, not a potency): 30%
For compound 4 the middle estimate is 4 percentage points below the measured one, and the stated range covers the measured number.
By their numbers in this assay, from the lowest: compounds 3, 4, 2 and 1 (each within the scatter of the next, the first and the last beyond it).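

In this assay, replacing sec-butyl with 2-(methylsulfanyl)ethyl on the saturated chain carbon bound to an amide-type nitrogen and a carbonyl carbon gives a number 4.4 percentage points higher from compound 3 to compound 4 (within the scatter) and is the first step shown at this place. It shows that this sulfur-bearing chain, which brings a hydrogen-bond acceptor, leaves the number within the scatter of that of the sec-butyl compound. Nothing available explains the size of this step. The compounds shown leave open whether an amine, a carboxylic acid or a longer chain at this place, with the rest of compound 3 unchanged, would move the number beyond the scatter.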